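Swapping the amide's aryl cap in a quinoline-ether series

This account rests on a few compounds, and the source may have more. Where it says the series, first, only, none or still open, it means among the compounds named here.

Compound 3, with structure `COc1ccc2nc(C)cc(OCC(=O)Nc3c(C)cccc3C)c2c1`, is the starting point. In a toxicity assay on HepG2 cells (Homo sapiens) for inhibition, read by CellTiter-Glo, with a stated time of 48 h (a higher number here means a weaker inhibitor, a lower number a stronger inhibitor), compound 3 gives > 100000 nM, which is a limit of the assay rather than a measured number. It shares this position with compound 1, whose structure is `COc1ccc2nc(C(F)(F)F)cc(OCC(=O)Nc3cc(C)cc(C)c3)c2c1`. In this assay compound 1 gives > 100000 nM, again a limit. Compound 3 therefore stands at the limit of > 100000 nM in this assay, at which 2 of the 3 values shown sit. Compound 2, with structure `COc1ccc2nc(C)cc(OCCNc3cc(C)cc(C)c3)c2c1`, carries a different linker between the shared core and the dimethylphenyl group. In this assay compound 2 gives 31600 nM.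

Compound 4, with structure `COc1ccc2nc(C)cc(OCC(=O)Nc3ccc(Cl)cc3)c2c1`, has not yet been measured. It differs from compound 3 in one place: 4-chlorophenyl in place of 2,6-dimethylphenyl on an amide-type nitrogen. Among the compounds with values here, no measured pair in this set isolates such a change, so its direction cannot be read from data. Because compound 3 gives > 100000 nM, only a limit, the expected step of an at least 1.2-fold lower number from compound 3 to compound 4 (0.09 log units; that floor lies within the scatter) is itself uncertain and likely no larger than the scatter. Compound 4 is estimated to give 80000 nM, within 20000 nM to 300000 nM.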

Compound 4, half-maximal inhibitory concentration: > 100000 nM
Compound 4: a limit, no number; the forecaster's own chance of this, stated with the estimate: 55%; middle value at least 1.2-fold (0.09 log units) from the limit.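

Compound 3 and compound 4 both sit at a limit of this assay rather than at a number, so no step can be read between them: the limit of > 100000 nM in this assay, at which 3 of the 4 values shown sit.

The compounds shown leave open whether 4-chlorophenyl in place of 2,6-dimethylphenyl on an amide-type nitrogen shifts the reading in this assay at all, and in which direction.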